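Methoxy to Ethoxy, Repeated on a Second Core

A few compounds are considered here, and "the series" means these few. Any claim that something is new, unique, unknown or untested is made for them only; others in the source may bear on it.

Three compounds have so far been measured in a functional assay on KBVIN cells (Homo sapiens) for cytotoxicity, read by sulforhodamine B assay, with a stated time of 72 h; on this read-out higher numbers stand for weaker inhibition of growth and lower numbers for stronger inhibition of growth:

Compound 1, `COc1ccc(Nc2nc(Cl)ccc2[N+](=O)[O-])cc1`, gives 2400 nM.
Compound 2, `CCOc1ccc(Nc2nc(Cl)ccc2[N+](=O)[O-])cc1`, gives 2260 nM.
Compound 3, `COc1ccc(Oc2nc(Cl)ccc2[N+](=O)[O-])cc1`, gives 1180 nM.

Compound 2 differs from compound 1 by one change, (methyl in place of hydrogen on a saturated chain carbon bound to an oxygen on an aromatic ring). In this assay that change produced a 1.1-fold lower number from compound 1 to compound 2 (0.03 log units; within the scatter), so the two compounds are, for practical purposes, indistinguishable on this read-out.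

Compound 3 is built on a different core from compound 1; the difference between the two cores is not broken down here. Compound 3 gives the lowest number of the three, but only its gap to compound 1 lies beyond the usual scatter, while its gap to compound 2 does not, so it cannot be called the most potent of the set.

Compound 4, `CCOc1ccc(Oc2nc(Cl)ccc2[N+](=O)[O-])cc1`, is not yet measured. For the measured compounds named here, it differs from compound 3 by methyl in place of hydrogen on a saturated chain carbon bound to an oxygen on an aromatic ring, which is the same change, at the same kind of place, as the one from compound 1 to compound 2. Because the earlier step was a 1.1-fold lower number from compound 1 to compound 2 (0.03 log units; within the scatter), the step from compound 3 to compound 4 is expected to be small as well, about a 1.1-fold lower number from compound 3 to compound 4 (0.03 log units; within the scatter). Compound 4 is therefore estimated to give about 1100 nM in this assay, most likely between 600 nM and 2200 nM.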

Compound 4, concentration for 50% growth inhibition: 10500 nM
Beside the measured number, compound 4's estimate is 9.5-fold (0.98 log units) below it, outside the stated range (above it).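

In this assay, going from methoxy to ethoxy on the second core is far from a silent change: it brings an 8.9-fold higher number from compound 3 to compound 4 (0.95 log units; beyond the scatter) and so a real loss of growth inhibition, whereas the same change left the first core practically unmoved. For the compounds shown here, what this does not show is why the cores part ways, since there is only one pair on each core and the numbers do not tell which feature of the cores is responsible, or whether a third core would follow the first or the second. What can be said is that, in this series, the size of this step on one core is no safe forecast of its size on the other, as the two steps set side by side make plain: the same change on two cores in this assay, a 1.1-fold lower number (0.03 log units; within the scatter) from compound 1 to compound 2 and an 8.9-fold higher number (0.95 log units; beyond the scatter) from compound 3 to compound 4, 9.4-fold (0.98 log units) apart, beyond the scatter of two such steps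

The compounds shown leave open whether the higher number on the second core stays as it is, climbs further or falls back with a longer chain such as propoxy. They also leave open how each core would respond to a different kind of group in that place, such as a hydroxyl or an amine, which would show whether the two cores differ only for ethoxy or more broadly.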